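Cyclopropyl in Place of Methyl on the Amide Nitrogen

A few compounds are considered here, and "the series" means these few. Any claim that something is new, unique, unknown or untested is made for them only; others in the source may bear on it.

Compound 1, `CC[C@H]1CN(c2ncc(C(N)=O)nc2C(F)(F)F)CCN1C1CCN(C(=O)c2ccc(Cl)nc2N)CC1`, gives 1.9 nM in an in vitro assay on BaF3 cells for displacement of a labelled ligand from C-X-C chemokine receptor type 3 (Homo sapiens); a lower number here means a stronger inhibitor, a higher number a weaker inhibitor.
Compound 2, `CC[C@H]1CN(c2ncc(C(=O)NC)nc2C(F)(F)F)CCN1C1CCN(C(=O)c2ccc(Cl)nc2N)CC1`, gives 1.5 nM in this assay.

Compound 2 and compound 1 sit within the scatter of each other, the step of a 1.3-fold lower number from compound 1 to compound 2 (0.10 log units; within the scatter) being too small to count. Compound 3, `CC[C@H]1CN(c2ncc(C(=O)NC3CC3)nc2C(F)(F)F)CCN1C1CCN(C(=O)c2ccc(Cl)nc2N)CC1`, takes this one step further: cyclopropyl in place of methyl on an amide-type nitrogen. For the measured compounds named here, the only measured step that bears on it is a 1.3-fold lower number from compound 1 to compound 2 (0.10 log units; within the scatter), which touched the same nitrogen and stayed within the scatter, so the expected step of no change at the digits printed from compound 2 to compound 3 (within the scatter) in this assay is none beyond the scatter. Compound 3 is estimated at 1.5 nM, between 0.6 nM and 4 nM.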

Compound 3, half-maximal inhibitory concentration: 1.8 nM
Compound 3: the middle estimate sits 1.2-fold (0.08 log units) below what was measured; the range from low to high includes it.
By their numbers in this assay, from the lowest: compounds 2, 3 and 1 (each within the scatter of the next).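

Cyclopropyl on the amide nitrogen gives a 1.2-fold higher number from compound 2 to compound 3 (0.08 log units; within the scatter) and a 1.1-fold lower number from compound 1 to compound 3 (0.02 log units; within the scatter) in this assay and so hydrogen, methyl and cyclopropyl at this position cannot be told apart. This position therefore accepts a three-membered ring as well as a single methyl without a change beyond the scatter. Nothing available explains why these three compounds read alike.

As far as these compounds go, what remains open is how a longer chain, a phenyl ring, or a chain ending in an amine or a carboxylic acid would read on this nitrogen.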